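From hydroxy to dimethylamino on a potent compound

A few compounds are considered here, and "the series" means these few. Any claim that something is new, unique, unknown or untested is made for them only; others in the source may bear on it.

Measured so far in a functional assay on HeLa cells (Homo sapiens) for antiproliferative activity, read by MTT assay, with a stated time of 48 h; a lower number here means a stronger inhibitor, a higher number a weaker inhibitor
- compound 1 `COc1ccc(C(=O)c2ccc3c(c2)C=CC(C)(C)O3)c(NC(=O)CN(C)C)c1` gives 1260 nM
- compound 2 `COc1ccc(C(=O)c2cc(OC)c(OC)c(OC)c2)c(NC(=O)CO)c1` gives 70 nM

Compound 2 (70 nM) has the lower of the two numbers, and its gap to compound 1 lies beyond the scatter. Compound 3 `COc1ccc(C(=O)c2cc(OC)c(OC)c(OC)c2)c(NC(=O)CN(C)C)c1` keeps the core of compound 2 but carries dimethylamino in place of hydroxy on a saturated chain carbon bound to a carbonyl carbon. Among the measured compounds shown here, no measured pair shows this change alone. Compound 1, which has the same dimethylamino chain, gives 1260 nM, but its core differs, so only a modest rise in the number is expected in this assay. The expected step is a 2.1-fold higher number from compound 2 to compound 3 (0.33 log units; beyond the scatter) and may prove smaller. For compound 3 the estimated value is 150 nM (range 35 nM to 650 nM).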

Compound 3, half-maximal inhibitory concentration: 470 nM
Estimate against measurement, compound 3: 3.1-fold (0.50 log units) below; measured number inside the range.
By their numbers in this assay, from the lowest: compound 2; then compound 3; then compound 1.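

In this assay, among the compounds shown here, putting dimethylamino in place of hydroxy on a saturated chain carbon bound to a carbonyl carbon gives a 6.7-fold higher number from compound 2 to compound 3 (0.83 log units; beyond the scatter), the first reading of this change on an unchanged core. The number at this position therefore depends on the group placed there. The change removes 1 hydrogen-bond donor and enlarges the group from 1 heavy atom to 3, but no measurement here ties the step to either difference.

On these data alone, whether a methoxy group, a primary amine or a longer chain would sit nearer compound 2 or compound 3 remains open. So does whether the change would cost the same on the core of compound 1.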